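Swapping the aryl group on the cinnamamide arm

The source may report more compounds than this note shows. Statements on the series, on what has been measured and on what is new or still open speak of the compounds shown alone.

Measured so far:
compound 1, `COc1ccc(C(=O)c2cc(OC)c(OC)c(OC)c2)cc1NC(=O)/C=C/c1ccc(OC)c(OC)c1` — 8900 nM
compound 2, `COc1cc(/C=C/C(=O)Nc2cc(C(=O)c3cc(OC)c(OC)c(OC)c3)ccc2OC)ccc1F` — 15500 nM

In a functional assay on ME-180 cells (Homo sapiens) for cytotoxicity, read by MTT assay, with a stated time of 72 h (a lower number here means a stronger inhibitor, a higher number a weaker inhibitor), compound 1 gives 8900 nM. Among the compounds with values here, compound 2, `COc1cc(/C=C/C(=O)Nc2cc(C(=O)c3cc(OC)c(OC)c(OC)c3)ccc2OC)ccc1F`, gives 15500 nM in this assay; this is the highest of the two numbers, but the only measured step, a 1.7-fold higher number from compound 1 to compound 2 (0.24 log units; within the scatter), stays within the scatter, so compound 1 and compound 2 cannot be told apart.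

Compound 3 is `COc1ccc(C(=O)c2cc(OC)c(OC)c(OC)c2)cc1NC(=O)/C=C/c1ccc([N+](=O)[O-])cc1`. It differs from compound 2 by 4-nitrophenyl in place of 4-fluoro-3-methoxyphenyl on a double-bonded chain carbon bound to a double-bonded chain carbon. Within the data shown here, the single known step concerns a methoxy-to-fluoro exchange on that same aryl group and stays within the scatter; it says nothing about replacing the whole group with a nitrophenyl. Among the measured compounds shown here, with no step bearing on this change, no shift beyond the scatter is expected, so the estimated step is a 1.3-fold lower number from compound 2 to compound 3 (0.11 log units; within the scatter).

For compound 3 the estimate in this assay is 12000 nM, with a range from 3000 nM to 45000 nM.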

Compound 3, half-maximal inhibitory concentration: 9300 nM
The estimate for compound 3 lay 1.3-fold (0.11 log units) above the measured number; the measured number falls inside the stated range.
By their numbers in this assay, from the lowest: compounds 1, 3 and 2 (each within the scatter of the next).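

Replacing the whole aryl group on this double-bonded chain carbon, rather than a single group on the ring, gives a 1.7-fold lower number from compound 2 to compound 3 (0.22 log units; within the scatter) in this assay and a 1.0-fold higher number from compound 1 to compound 3 (0.02 log units; within the scatter) when 3,4-dimethoxyphenyl is the group that leaves. So 4-fluoro-3-methoxyphenyl, 3,4-dimethoxyphenyl and 4-nitrophenyl cannot be told apart here, even though the entering ring carries a nitro group and no methoxy group. Nothing at hand explains why these three groups read alike.

As far as these compounds go, it remains open whether a group without an aromatic ring, such as a plain alkyl chain, or a phenyl ring carrying an amine or a carboxylic acid, would move the number beyond the scatter. None of the steps shown on this arm has done that so far.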